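This account rests on a few compounds, and the source may have more. Where it says the series, first, only, none or still open, it means among the compounds named here.

Measured compounds:
compound 1 `O=C(NCc1cn(Cc2ccc(C(F)(F)F)cc2)nn1)c1cn(-c2ccccc2)nc1-c1ccccc1` — 17700 nM
compound 2 `O=C(NCc1cn(Cc2ccc(C(F)(F)F)cc2)nn1)c1cn(-c2ccccc2)nc1-c1ccc(F)cc1` — 760 nM
compound 3 `O=C(NCc1cn(Cc2ccc(C(F)(F)F)cc2)nn1)c1cn(-c2ccccc2)nc1-c1ccc(Cl)cc1` — 1100 nM

All three were tested in a functional assay on MIA PaCa-2 cells (Homo sapiens) for antiproliferative activity, read by sulforhodamine B assay, with a stated time of 48 h; a higher number here means a weaker inhibitor of growth, a lower number a stronger inhibitor of growth. Compound 3 stands second highest of the three numbers: compound 2 sits close, since a 1.4-fold higher number from compound 2 to compound 3 (0.16 log units; within the scatter) lies within the scatter, while compound 1 lies far off, as a 16-fold lower number from compound 1 to compound 3 (1.21 log units; beyond the scatter) shows. Compound 4 `COc1cc(Cn2cc(CNC(=O)c3cn(-c4ccccc4)nc3-c3ccc(Cl)cc3)nn2)cc(OC)c1OC` is not yet measured. It differs from compound 3 by 3,4,5-trimethoxyphenyl in place of 4-(trifluoromethyl)phenyl on a saturated chain carbon bound to an aromatic nitrogen. The measured steps, a 23-fold lower number from compound 1 to compound 2 (1.37 log units; beyond the scatter) and a 16-fold lower number from compound 1 to compound 3 (1.21 log units; beyond the scatter), each exchange a group on an aromatic carbon of the shared core, so none of them bears on this change; the data give no guide for the new group. The expected step is a 1.2-fold lower number from compound 3 to compound 4 (0.09 log units; within the scatter), nothing beyond the scatter. Compound 4 is expected to give about 900 nM, within a range from 200 nM to 5000 nM, in this assay.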

Compound 4, concentration for 50% growth inhibition: 3500 nM
Compound 4: middle estimate off by 3.9-fold (0.59 log units), on the low side; the range from low to high includes it.
By their numbers in this assay, from the lowest: compounds 2 and 3 (each within the scatter of the next); then compound 4; then compound 1.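

In this assay the step from the 4-(trifluoromethyl)phenyl group to 3,4,5-trimethoxyphenyl, on a saturated chain carbon bound to an aromatic nitrogen, gives a 3.2-fold higher number from compound 3 to compound 4 (0.50 log units; beyond the scatter) and so shows that growth inhibition responds to this position too, not only to changes on the shared core. The loss is modest, and compound 4 remains well short of the number for compound 1. No measurement available here accounts for this loss. Open questions are whether a single methoxy group or an amine on this phenyl ring would land nearer compound 3 or compound 4, and whether the same exchange has a similar effect with fluoro in place of chloro on the core.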